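This account rests on a few compounds, and the source may have more. Where it says the series, first, only, none or still open, it means among the compounds named here.

Of the compounds shown here, three have been measured in an ADME assay on LLC-MK2 cells (Macaca mulatta) for cytotoxicity, read by spectrophotometry and crystal violet staining, with a stated time of 4 days; on this read-out lower numbers stand for higher toxicity in this test and higher numbers for lower toxicity in this test.

Compound 1 `CC(C)n1ncc2c(C(=O)Nc3ccccn3)cc(-c3ccsc3)nc21` gives 25000 nM.
Compound 2 `CC(C)n1ncc2c(C(=O)Nc3ccncn3)cc(-c3ccsc3)nc21` gives only a limit of the assay, > 200000 nM.
Compound 3 `CC(C)n1ncc2c(C(=O)Nc3ccccn3)cc(-c3cccs3)nc21` likewise gives only a limit of the assay, > 200000 nM.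

Compound 4 `CC(C)n1ncc2c(C(=O)Nc3ccncn3)cc(-c3cccs3)nc21` is not yet measured. It differs from compound 3 by pyrimidin-4-yl in place of pyridin-2-yl on an amide-type nitrogen. The same change, (pyrimidin-4-yl in place of pyridin-2-yl on an amide-type nitrogen), is made from compound 1 to compound 2, where it gave an at least 8.0-fold higher number from compound 1 to compound 2 (0.90 log units; beyond the scatter), the end point of that step being set by the limit of > 200000 nM in this assay, at which 2 of the 3 values shown sit. The two cores differ by thiophen-2-yl in place of thiophen-3-yl on an aromatic carbon, which on its own gave an at least 8.0-fold higher number from compound 1 to compound 3 (0.90 log units; beyond the scatter), again running into (the limit of > 200000 nM in this assay, at which 2 of the 3 values shown sit). Compound 3 therefore already stands at the limit before the change is made. If the change acts as it did before, compound 4 is expected to stay at or beyond that limit, the expected step being a step that the limit leaves unreadable from compound 3 to compound 4, on the pattern of an at least 8.0-fold higher number from compound 1 to compound 2 (0.90 log units; beyond the scatter). The estimate for compound 4 is 250000 nM, between 150000 nM and 800000 nM, though the assay would most likely again report only a limit.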

Compound 4, half-maximal cytotoxic concentration: 50000 nM
The estimate for compound 4 lay 5.0-fold (0.70 log units) above the measured number; measured number outside the range, below it.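

In this assay, pyrimidin-4-yl in place of pyridin-2-yl on an amide-type nitrogen gave an at least 4.0-fold lower number from compound 3 to compound 4 (0.60 log units; beyond the scatter), so on the core of compound 3 the change ran opposite to its direction on the core of compound 1: the same change on two cores in this assay, an at least 8.0-fold higher number (0.90 log units; beyond the scatter) from compound 1 to compound 2 and an at least 4.0-fold lower number (0.60 log units; beyond the scatter) from compound 3 to compound 4, at least 32-fold (1.50 log units) apart, beyond the scatter of two such steps

The other change also reversed, with thiophen-2-yl in place of thiophen-3-yl on an aromatic carbon giving an at least 4.0-fold lower number from compound 2 to compound 4 (0.60 log units; beyond the scatter), against its direction when the amide-type nitrogen carries pyridin-2-yl: the same change on two cores in this assay, an at least 8.0-fold higher number (0.90 log units; beyond the scatter) from compound 1 to compound 3 and an at least 4.0-fold lower number (0.60 log units; beyond the scatter) from compound 2 to compound 4, at least 32-fold (1.50 log units) apart, beyond the scatter of two such steps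

The two changes therefore do not act independently across these four compounds, but the sizes of the steps remain minimum figures, and this single set does not show how either change would behave on any further core, since the steps rest on a limit: the limit of > 200000 nM in this assay, at which 2 of the 4 values shown sit.

As far as these compounds go, how far compound 2 and compound 3 actually lie beyond that limit stays open. So does whether the reversal would persist with phenyl or furan-2-yl on the aromatic carbon, or with pyrazin-2-yl on the amide-type nitrogen.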